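Replacing the Distal Aromatic Ring: A Step Expected Flat

The source may report more compounds than this note shows. Statements on the series, on what has been measured and on what is new or still open speak of the compounds shown alone.

Two measured compounds share one core and differ only in the aromatic ring at the far end. Compound 1 `FC(F)(F)c1ccccc1-c1nc(NCc2ccc(-c3cccc(Cl)c3)cc2)c2ccccc2n1` carries a 3-chlorophenyl there, and in an assay on a protein complex for inhibition of ubiquitin carboxyl-terminal hydrolase 1/WD repeat-containing protein 48 (Homo sapiens), read by fluorescence (on this read-out lower numbers stand for stronger inhibition and higher numbers for weaker inhibition), compound 1 gives 2700 nM. Compound 2 `FC(F)(F)c1ccccc1-c1nc(NCc2ccc(-c3cncnc3)cc2)c2ccccc2n1` carries a pyrimidin-5-yl instead, and in this assay compound 2 gives 3000 nM. The step of a 1.1-fold higher number from compound 1 to compound 2 (0.05 log units; within the scatter) shows that this exchange left the number within the scatter. Compound 2 thus holds the higher of the two numbers, but compound 1 sits within the scatter of it, so no order between them can be read.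

Compound 3 `FC(F)(F)c1cc(-c2ccc(CNc3nc(-c4ccccc4C(F)(F)F)nc4ccccc34)cc2)ccn1` makes a further exchange at the same place: 2-(trifluoromethyl)pyridin-4-yl in place of pyrimidin-5-yl on an aromatic carbon. Within the data shown here, the only measured step that bears on it is the one between compound 1 and compound 2, which also swapped one aromatic ring for another at this point and stayed within the scatter. Compound 3 is therefore expected to show a 1.1-fold lower number from compound 2 to compound 3 (0.03 log units; within the scatter) in this assay, no step beyond the scatter. The estimate for compound 3 is 2800 nM, with a range from 1200 nM to 6500 nM.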

Compound 3, half-maximal inhibitory concentration: 4900 nM
Compound 3: the middle estimate sits 1.8-fold (0.24 log units) below what was measured, and the stated range covers the measured number.
By their numbers in this assay, from the lowest: compounds 1, 2 and 3 (each within the scatter of the next).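

In this assay, the exchange of pyrimidin-5-yl for 2-(trifluoromethyl)pyridin-4-yl gives a small step (a 1.6-fold higher number from compound 2 to compound 3 (0.21 log units; within the scatter)), even though the entering group has 10 heavy atoms against 6 and one hydrogen-bond acceptor against 2. Among these compounds, the exchange of 3-chlorophenyl for the same group also stays small (a 1.8-fold higher number from compound 1 to compound 3 (0.26 log units; within the scatter)), so this place on the aromatic carbon, para to a large group, now holds three different six-membered aromatic rings, with no hetero atom, 1 or 2, and all three numbers lie within the scatter of one another, which the first pair alone, with only two rings, could not show. Nothing available here accounts for this flat response.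

What these compounds leave open is whether the number would move at this place with something other than an aromatic ring, such as a carboxylic acid, a primary amine or a morpholine. They also leave open whether a ring at this place is needed at all, as a compound with only hydrogen there would show.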